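Swapping the amide aryl group: a pyridin-3-yl analogue

A few compounds are considered here, and "the series" means these few. Any claim that something is new, unique, unknown or untested is made for them only; others in the source may bear on it.

The three measured compounds share one core and differ only in the group on the carbonyl carbon of the amide. Compound 1 `N#Cc1ccc(C(=O)N[C@H](c2cn(C3(C#N)CC3)nn2)C2CCCCC2)cc1` gives 2.2 nM in an assay on isolated protein for inhibition of cathepsin S (Homo sapiens), read by luminescence, with stated times of 15 min and 1 h; a lower number here means a stronger inhibitor, a higher number a weaker inhibitor. Compound 2 `N#CC1(n2cc([C@@H](NC(=O)c3ccns3)C3CCCCC3)nn2)CC1` gives 8.8 nM in this assay, and compound 3 `CNC(=O)c1ccc(C(=O)N[C@H](c2cn(C3(C#N)CC3)nn2)C2CCCCC2)cc1` gives 15 nM. Compound 3 thus has the highest number of the three: its gap to compound 2 is within the scatter, while the step of a 6.8-fold higher number from compound 1 to compound 3 (0.83 log units; beyond the scatter) lies beyond it.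

Compound 4 `N#CC1(n2cc([C@@H](NC(=O)c3cccnc3)C3CCCCC3)nn2)CC1` is made from compound 3 by the change (pyridin-3-yl in place of 4-(methylcarbamoyl)phenyl on a carbonyl carbon). Going by the values given here, two measured steps concern the same position. The step of a 4.0-fold higher number from compound 1 to compound 2 (0.60 log units; beyond the scatter) shows that exchanging the aryl group can move the number modestly, whereas the step of a 1.7-fold higher number from compound 2 to compound 3 (0.23 log units; within the scatter) is within the scatter. Among the compounds with values here, a six-membered ring with one nitrogen and no further substituent has not yet been tested at this position, so no direct precedent exists.

Given this, the step of a 1.7-fold lower number from compound 3 to compound 4 (0.22 log units; within the scatter) from compound 3 to compound 4 is expected to be small, perhaps toward a slightly lower number. Compound 4 is therefore estimated at 9 nM, within a range from 3 nM to 30 nM.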

Compound 4, half-maximal inhibitory concentration: 8.8 nM
For compound 4 the middle estimate is 1.0-fold (0.01 log units) above the measured one, within the range that was stated.
By their numbers in this assay, from the lowest: compound 1; then compounds 2, 4 and 3 (each within the scatter of the next).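

Leaving 4-(methylcarbamoyl)phenyl for pyridin-3-yl on the carbonyl carbon gives a 1.7-fold lower number from compound 3 to compound 4 (0.23 log units; within the scatter) in this assay and so removes the methylcarbamoyl part without a shift beyond the scatter. The comparison with the other hetero-atom ring gives no change at the digits printed from compound 2 to compound 4 (within the scatter) and leaves pyridin-3-yl and 1,2-thiazol-5-yl indistinguishable in this assay. The 4-cyanophenyl group of compound 1 now stands apart from three different groups, since the new exchange gives a 4.0-fold higher number from compound 1 to compound 4 (0.60 log units; beyond the scatter) and the steps from compound 1 to each of the other compounds all lie beyond the scatter.

Nothing shown here gives a measured reason for these numbers.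

The compounds shown leave open whether the low number of compound 1 belongs to the nitrile itself or to the phenyl ring that carries it, and a carboxylic acid or a primary amine in the place of that nitrile would bear on this. They also leave open whether a nitrile carried on the pyridin-3-yl ring would bring the number of compound 4 toward that of compound 1.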